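A few compounds are considered here, and "the series" means these few. Any claim that something is new, unique, unknown or untested is made for them only; others in the source may bear on it.

Series in a functional assay on HT-29 cells (Homo sapiens) for antiproliferative activity, read by MTT assay, with a stated time of 72 h; on this read-out higher numbers stand for weaker inhibition and lower numbers for stronger inhibition:
compound 1 `CCn1ccnc1-c1cc(OC)c(OC)c(OC)c1`: > 100000 nM (a limit of the assay, not a number)
compound 2 `CCCCCn1ccnc1-c1cc(OC)c(OC)c(OC)c1`: 60100 nM
compound 3 `COc1cc(-c2nccn2-c2cccc(C)c2)cc(OC)c1OC`: 14600 nM

Compound 3 has the lowest of the two actual numbers, and the nearest is compound 2. The gap is a 4.1-fold lower number from compound 2 to compound 3 (0.61 log units; beyond the scatter). Against the limit of compound 1, the step is an at least 6.8-fold lower number from compound 1 to compound 3 (0.83 log units; beyond the scatter).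

Next is compound 4 `COc1cc(-c2nccn2-c2ccc(F)cc2)cc(OC)c1OC`, with 4-fluorophenyl in place of 3-methylphenyl on an aromatic nitrogen. The place is the one changed in the two steps above, and in both of them 3-methylphenyl replaced a chain. Neither step exchanges one substituted phenyl for another, so neither gives a measured size for this change. They do suggest that compound 4 keeps the lower range reached by compound 3, given the modest 4.1-fold lower number from compound 2 to compound 3 (0.61 log units; beyond the scatter). Among the measured compounds shown here, only one phenyl example has been measured, so the range stays wide.

No step beyond the scatter is expected in this assay, and the direction is open. The expected step is a 1.1-fold lower number from compound 3 to compound 4 (0.05 log units; within the scatter).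

For compound 4 the estimated value is 13000 nM, with an expected range of 3500 nM to 50000 nM.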

Compound 4, half-maximal inhibitory concentration: 29300 nM
Beside the measured number, compound 4's estimate is 2.3-fold (0.35 log units) below it, within the range that was stated.
By their numbers in this assay, from the lowest: compounds 3 and 4 (each within the scatter of the next); then compound 2. At a limit, above all of these: compound 1.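

In this assay, among the compounds shown here, this is the first exchange of one substituted phenyl for another on the aromatic nitrogen, and it gives a 2.0-fold higher number from compound 3 to compound 4 (0.30 log units; within the scatter), so 3-methylphenyl and 4-fluorophenyl are not separated at this position. The lower range against the pentyl chain also no longer rests on 3-methylphenyl alone, with 4-fluorophenyl giving a 2.1-fold lower number from compound 2 to compound 4 (0.31 log units; beyond the scatter), a modest step that is only just beyond the scatter. Against the ethyl chain the reading is an at least 3.4-fold lower number from compound 1 to compound 4 (0.53 log units; beyond the scatter), and that figure is only a floor, as it rests on a limit and not on a number: the limit of > 100000 nM in this assay, at which 1 of the 4 values shown sits.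

The 3-methylphenyl and 4-fluorophenyl groups differ both in the substituent and in where it sits on the phenyl ring, so unsubstituted phenyl, 4-methylphenyl and 3-fluorophenyl on this nitrogen are the groups that would pull those two changes apart. Also open, on these data alone, is whether a phenyl carrying an amine or a carboxylic acid, or a chain longer than pentyl, would move the number outside the range seen so far.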